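A few compounds are considered here, and "the series" means these few. Any claim that something is new, unique, unknown or untested is made for them only; others in the source may bear on it.

In a functional assay on MIA PaCa-2 cells (Homo sapiens) for cytotoxicity, read by WST assay, with a stated time of 48 h (a lower number here means a stronger inhibitor, a higher number a weaker inhibitor), compound 1, with the structure `N#C/C(=C\c1c[nH]c2cc(F)ccc12)C(=O)c1c[nH]c2ccccc12`, gives 31600 nM. Compound 2, with the structure `COc1ccc2[nH]cc(C(=O)/C(C#N)=C/c3c[nH]c4cc(F)ccc34)c2c1`, reaches only the limit of the assay in this assay, recorded as > 50000 nM. Compound 3, with the structure `COc1ccc2c(C(=O)/C(C#N)=C/c3cn(Cc4ccc(Cl)cc4)c4ccccc34)c[nH]c2c1`, gives 40400 nM in this assay, the highest of the two numbers that were measured, though its gap to compound 1 is within the scatter of repeated measurements.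

Between compound 2 and compound 1 the only change is hydrogen in place of methoxy on an aromatic carbon, and the step it made was an at least 1.5-fold lower number from compound 2 to compound 1 (0.19 log units; that floor lies within the scatter); the size of that step rests on the limit of > 50000 nM in this assay, at which 1 of the 3 values shown sits, at which compound 2 sits, so its floor is all that can be stated. The difference between the cores of compound 2 and compound 3 is not broken down here.

Compound 4, with the structure `N#C/C(=C\c1cn(Cc2ccc(Cl)cc2)c2ccccc12)C(=O)c1c[nH]c2ccccc12`, is yet to be measured in this assay. It differs from compound 3 by hydrogen in place of methoxy on an aromatic carbon, the same change as that from compound 2 to compound 1, made at a place described in the same words. From compound 3 to compound 4 the account therefore expects a step of about a 1.6-fold lower number from compound 3 to compound 4 (0.21 log units; within the scatter), a modest movement toward a lower number, resting on the step of an at least 1.5-fold lower number from compound 2 to compound 1 (0.19 log units; that floor lies within the scatter) and on the starting point that compound 3 gives 40400 nM. On that basis compound 4 is estimated to give 25000 nM in this assay, with a plausible range from 10000 nM to 60000 nM.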

Compound 4, half-maximal inhibitory concentration: > 50000 nM
Compound 4 gave a limit, no number; the forecaster's own chance of this, stated with the estimate: 15%; middle value at least 2.0-fold (0.30 log units) away from the limit.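

Exchanging methoxy for hydrogen on the core of compound 3 gives, in this assay, a step that can be stated only as a floor, an at least 1.2-fold higher number from compound 3 to compound 4 (0.09 log units; that floor lies within the scatter), since the value for compound 4 is a limit of the assay and not a number. This does not show that the change acts in opposite directions on the two cores, nor that it carries over from one core to the other unchanged, and the two floors can be read only as follows: the same change on two cores in this assay, an at least 1.5-fold lower number (0.19 log units; that floor lies within the scatter) from compound 2 to compound 1 and an at least 1.2-fold higher number (0.09 log units; that floor lies within the scatter) from compound 3 to compound 4; the limit leaves it open whether they differ. Neither step has a measured size, since compound 2 and compound 4 both stand at a limit and how far either lies past it cannot be told: the limit of > 50000 nM in this assay, at which 2 of the 4 values shown sit.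

The compounds shown leave open whether a different group at this place, such as a hydroxyl, a fluorine or an amine, would give a number inside the range of this assay on both cores. They also leave open whether a longer chain, such as ethoxy, would behave alike on the core of compound 1 and the core of compound 4.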